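The compounds below may be only part of what the source reports. "The series", "measured", "known", "first", "only" and "open" are said of these compounds alone.

Measured so far:
- compound 1 `O=C1C=C(Nc2ccc(I)cc2)C(=O)c2c1nc1n2[C@H]2OC[C@@H](O)[C@H]2OC1` — in a functional assay on MCF7 cells (Homo sapiens) for inhibition, read by sulforhodamine B assay (on this read-out higher numbers stand for weaker inhibition and lower numbers for stronger inhibition), compound 1 gives 2230 nM
- compound 2 `COc1cccc(NC2=CC(=O)c3c(nc4n3[C@H]3OC[C@@H](O)[C@H]3OC4)C2=O)c1` — compound 2 gives 3830 nM
- compound 3 `O=C1C=C(Nc2ccc(C(F)(F)F)cc2)C(=O)c2c1nc1n2[C@H]2OC[C@@H](O)[C@H]2OC1` — compound 3 gives > 4000 nM

The value for compound 3 is a limit of this assay, (the limit of > 4000 nM in this assay, at which 1 of the 3 values shown sits), not a number. Compound 2 has the highest of the two numbers, yet its gap to compound 1 lies within the scatter, so the two cannot be told apart. Among the measured compounds shown here, the one measured step, an at least 1.7-fold higher number from compound 1 to compound 3 (0.25 log units; that floor lies within the scatter), concerns a different change and does not reach beyond the scatter. Compound 4 `O=C1C(Nc2cccc(F)c2)=CC(=O)c2c1nc1n2[C@H]2OC[C@@H](O)[C@H]2OC1` differs from compound 2 by fluoro in place of methoxy on an aromatic carbon. For the measured compounds named here, no measured step bears on this change, so no shift beyond the scatter is expected; the step from compound 2 to compound 4 is estimated as a 1.0-fold lower number from compound 2 to compound 4 (0.00 log units; within the scatter). Compound 4 is therefore expected to give about 3800 nM, between 1800 nM and 8000 nM.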

Compound 4, half-maximal inhibitory concentration: > 4000 nM
Compound 4 ended at the assay's limit (the forecaster's own chance of this, stated with the estimate: 40%); middle value at least 1.0-fold (0.02 log units) from the limit.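

In this assay, going from 3-methoxyphenyl to 3-fluorophenyl gives an at least 1.0-fold higher number from compound 2 to compound 4 (0.01 log units; that floor lies within the scatter), so this position now has its first measured step, and that step shows no shift beyond the scatter. On these data alone, compound 4 gives > 4000 nM, which is a limit of the assay and not a number, so the true size of the step stays unknown. A second compound now sits at that ceiling: the limit of > 4000 nM in this assay, at which 2 of the 4 values shown sit.

As far as these compounds go, how far compound 4 lies past the limit remains open. So does how this position would respond to an amine or a carboxylic acid in place of methoxy or fluoro.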